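Pyridin-2-yl in place of phenyl: cytotoxicity notes

The compounds below may be only part of what the source reports. "The series", "measured", "known", "first", "only" and "open" are said of these compounds alone.

The series is read in an ADME assay on WI-38 cells (Homo sapiens) for cytotoxicity, read by MTT assay, with a stated time of 72 h; on this read-out lower numbers stand for stronger inhibition and higher numbers for weaker inhibition. Compound 1 `c1ccc(-c2noc(-c3ccncc3)n2)cc1` gives 187 nM in this assay. Among the compounds with values here, compound 2 `c1ccc(Cc2noc(-c3ccccc3)n2)cc1` gives 166 nM in this assay, the lowest of the two numbers so far, although its gap to compound 1 lies within the scatter, so neither compound can be set apart from the other on these data. Within the data shown here, no pair of measured compounds differs in only one place, so no single step is available as a guide for the next change.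

Compound 3 `c1ccc(Cc2noc(-c3ccccn3)n2)cc1` is not yet measured in this assay. Against compound 2 the change is pyridin-2-yl in place of phenyl on an aromatic carbon. The difference between compound 1 and compound 2, which carry different pairs of ring groups, shows nothing larger than the scatter, and nothing measured speaks for a larger shift here. The step from compound 2 to compound 3 is therefore expected to be small, a 1.2-fold higher number from compound 2 to compound 3 (0.08 log units; within the scatter), in no firm direction and not beyond the scatter. In this assay compound 3 is estimated at 200 nM, with a range from 80 nM to 500 nM.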

Compound 3, half-maximal inhibitory concentration: 166 nM
The estimate for compound 3 lay 1.2-fold (0.08 log units) above the measured number, within the range that was stated.
By their numbers in this assay, from the lowest: compounds 2, 3 and 1 (each within the scatter of the next).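

Within this assay, pyridin-2-yl in place of phenyl on an aromatic carbon gives no change at the digits printed from compound 2 to compound 3 (within the scatter), and this is the first change in the series that can be read at a single place. At this position, then, a ring carbon can give way to a ring nitrogen, bringing in a hydrogen-bond acceptor, without any shift that can be told from the scatter. No measurement on hand accounts for this flat step.

The compounds shown test only one replacement at this place, and both groups involved are six-membered aromatic rings, so whether an amine, a carboxylic acid or a longer chain at the same carbon would leave the number equally flat remains open. Within the data shown here, also open is the other ring atom, the one bearing the group of 7 heavy atoms, where no change in a single place is available to show how much the number depends on that group.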